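Carbonyl substituent variation on a shared core

A few compounds are considered here, and "the series" means these few. Any claim that something is new, unique, unknown or untested is made for them only; others in the source may bear on it.

Measured so far:
compound 1 `CC1(C)Cc2c(sc(NC(=O)c3nnc[nH]3)c2C(N)=O)C(C)(C)O1`: 467 nM
compound 2 `CC1(C)Cc2c(sc(NC(=O)C3(O)CC3)c2C(N)=O)C(C)(C)O1`: 23 nM
compound 3 `CC1(C)Cc2c(sc(NC(=O)C(C)(C)O)c2C(N)=O)C(C)(C)O1`: 16 nM

In an assay on cells for positive allosteric modulation of Cystic fibrosis transmembrane conductance regulator variant F508del (Homo sapiens), with stated times of 10 min and 7 s, in the presence of a further agent that is not named here (a higher number here means that more compound is needed for the effect, a lower number that less compound is needed), compound 3 carries the lowest of the three numbers, but compound 2 is not separated from it beyond the scatter a 1.4-fold lower number from compound 2 to compound 3 (0.16 log units; within the scatter). Against compound 1 the gap is large a 29-fold lower number from compound 1 to compound 3 (1.47 log units; beyond the scatter), and compound 2 shows the same kind of gap against compound 1 a 20-fold lower number from compound 1 to compound 2 (1.31 log units; beyond the scatter).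

The unmeasured compound 4 `CC1(C)Cc2c(sc(NC(=O)c3cc(C(F)(F)F)n[nH]3)c2C(N)=O)C(C)(C)O1` differs from compound 3 by 3-(trifluoromethyl)-1H-pyrazol-5-yl in place of 1-hydroxy-1-methylethyl on a carbonyl carbon. Going by the values given here, two measured steps bear on this: both moved from the five-membered aromatic ring of compound 1 to a hydroxy-bearing group and gave large reductions in this assay. The step to compound 4 runs the other way, restoring a five-membered aromatic ring with two hetero atoms on the carbonyl carbon. Among the compounds with values here, no measured pair tells how a trifluoromethyl-substituted pyrazolyl compares with the triazolyl of compound 1, so the size is uncertain, but a rise in this assay is expected, of roughly the magnitude seen between compound 3 and compound 1 a 29-fold lower number from compound 1 to compound 3 (1.47 log units; beyond the scatter). For compound 4 the expected step is a 16-fold higher number from compound 3 to compound 4 (1.19 log units; beyond the scatter), giving an estimated 250 nM with a range from 50 nM to 1200 nM.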

Compound 4, half-maximal effective concentration: 3 nM
Compound 4: middle estimate off by 83-fold (1.92 log units), on the high side, outside the stated range (below it).
By their numbers in this assay, from the lowest: compound 4; then compounds 3 and 2 (each within the scatter of the next); then compound 1.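

At this carbonyl position, a five-membered aromatic ring can give a lower number in this assay than either hydroxy-bearing group, as the 3-(trifluoromethyl)-1H-pyrazol-5-yl group shows (a 5.3-fold lower number from compound 3 to compound 4 (0.73 log units; beyond the scatter); a 7.7-fold lower number from compound 2 to compound 4 (0.88 log units; beyond the scatter)). Going by these compounds alone, with the 4H-1,2,4-triazol-3-yl group as the only aromatic example, the earlier compounds left the aromatic ring looking unfavourable, but aromatic groups now occupy both ends of the series (a 160-fold lower number from compound 1 to compound 4 (2.19 log units; beyond the scatter)), so the mere presence of such a ring does not set the number. Nothing available accounts for the gain or assigns a cause to this change.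

The share of the pyrazolyl ring and of its trifluoromethyl group in the gain remains unassigned, and a pyrazolyl ring bearing a methyl group or a chlorine atom in place of trifluoromethyl would help separate them. Also open, from the compounds shown here alone, is how a carboxylic acid or an amine on the same ring would read in this assay, and whether the trifluoromethyl group would bring a similar change on the 4H-1,2,4-triazol-3-yl ring of compound 1.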